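Chain Extension Across Two Related Amide Cores

The source may hold more compounds than are shown below. What is called first, only, known or untested is meant among the compounds shown, and "the series" means these compounds.

Compound 1 `CCCCCCCCCCCCCCCCNC(=O)c1c[nH]c(-c2ccccc2)n1` and compound 2 `CCCCCCCCCCCCCCCCCCNC(=O)c1c[nH]c(-c2ccccc2)n1` share one core, while compound 3 `CCCCCCCCCCCCCCNC(=O)[C@@H]1CNC(c2ccccc2)=N1` and compound 4 `CCCCCCCCCCCCCCCCNC(=O)[C@@H]1CNC(c2ccccc2)=N1` share another; the difference between the two cores is not broken down here. In a functional assay on A-375 cells (Homo sapiens) for antiproliferative activity, read by sulforhodamine B assay, with a stated time of 48 h (on this read-out higher numbers stand for weaker inhibition and lower numbers for stronger inhibition), compound 1 gives 16500 nM, and compound 2 gives 20700 nM. The change between them, (ethyl in place of hydrogen on a saturated chain carbon, ten or more bonds along the chain from an amide-type nitrogen), produced a 1.3-fold higher number from compound 1 to compound 2 (0.10 log units; within the scatter). In this assay compound 3 gives 7100 nM, the lowest of the three numbers and beyond the scatter from both others. Compound 4 carries the same change, (ethyl in place of hydrogen on a saturated chain carbon, ten or more bonds along the chain from an amide-type nitrogen), placed on the other core. Because a 1.3-fold higher number from compound 1 to compound 2 (0.10 log units; within the scatter) lay within the scatter, an equally small step is expected, a 1.2-fold higher number from compound 3 to compound 4 (0.08 log units; within the scatter). Compound 4 is therefore estimated at 8500 nM, with a likely range from 4000 nM to 18000 nM.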

Compound 4, half-maximal inhibitory concentration: 10500 nM
The estimate for compound 4 lay 1.2-fold (0.09 log units) below the measured number, within the range that was stated.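

In this assay, ethyl in place of hydrogen on the saturated chain carbon gave a 1.5-fold higher number from compound 3 to compound 4 (0.17 log units; within the scatter), a step as small on this core as on the other. Set side by side, the two steps do not differ: the same change on two cores in this assay, a 1.3-fold higher number (0.10 log units; within the scatter) from compound 1 to compound 2 and a 1.5-fold higher number (0.17 log units; within the scatter) from compound 3 to compound 4, 1.2-fold (0.07 log units) apart, within the scatter of two such steps. This shows that, for these two pairs, the change carries from one core to the other without a step that stands out from the scatter, but it does not show that the change moves the number on either core, or that the same would hold on any further core.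

The compounds shown leave open whether a much shorter chain would also give so small a step on both cores. They also leave open how a chain ending in an amine or a carboxylic acid would behave.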